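The source may hold more compounds than are shown below. What is called first, only, known or untested is meant among the compounds shown, and "the series" means these compounds.

Measured so far in a physicochemical assay for lipophilicity, using the shake flask method, in phosphate buffer, measured as octanol-water partition, with a stated time of 30 min, at pH 7.4; a higher number here means a more lipophilic compound, a lower number a more polar compound:

- Compound 1 `Cc1nccn1-c1cnc(NCc2c(F)ccc3c2CCO3)c2cn[nH]c(=O)c12`: 2.1
- Compound 2 `CC(=O)N1CCC(c2cnc(NCc3c(F)ccc4c3CCO4)c3cn[nH]c(=O)c23)CC1`: 2.9
- Compound 3 `CC1(C)CC(=O)N(c2cnc(NCc3c(F)ccc4c3CCO4)n3cnnc23)C1`: 2

Compound 2, at 2.9, holds the highest of the three numbers, and its gaps to compound 1 and compound 3 both lie beyond the scatter. Compound 4 `Cc1cc(-c2cnc(NCc3c(F)ccc4c3CCO4)c3cn[nH]c(=O)c23)n(C)n1` has yet to be measured. It differs from compound 2 in one place, with 1,3-dimethyl-1H-pyrazol-5-yl in place of 1-acetylpiperidin-4-yl on an aromatic carbon.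

Going by the values given here, only one measured step bears on this change: a number 0.80 log units higher from compound 1 to compound 2 (beyond the scatter), which came with 1-acetylpiperidin-4-yl in place of 2-methyl-1H-imidazol-1-yl on an aromatic carbon. Among the compounds with values here, compound 3 differs from the others in more than one place and offers no comparable step. The group entering compound 4 resembles the 2-methyl-1H-imidazol-1-yl of compound 1 more closely than it resembles the group it replaces, but the two are not the same. Part of the measured rise is therefore expected to be given back, so the direction should be downward, with a smaller size and perhaps no clear move beyond the scatter. The expected change is a number 0.30 log units lower from compound 2 to compound 4 (within the scatter). For compound 4 the estimated value in this assay is 2.6, with an expected range from 2.2 to 3.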

Compound 4, distribution coefficient: 3
For compound 4 the middle estimate is 0.40 log units below the measured one; the range from low to high includes it.
By their numbers in this assay, from the lowest: compounds 3 and 1 (each within the scatter of the next); then compounds 2 and 4 (each within the scatter of the next).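

In this assay, 1,3-dimethyl-1H-pyrazol-5-yl in place of 1-acetylpiperidin-4-yl on this aromatic carbon gives a number 0.10 log units higher from compound 2 to compound 4 (within the scatter), so a five-membered aromatic ring and a six-membered non-aromatic ring cannot be told apart here, despite their different heavy-atom counts and the loss of the double bond outside aromatic rings. With 2-methyl-1H-imidazol-1-yl as the reference, the same group gives a number 0.90 log units higher from compound 1 to compound 4 (beyond the scatter), a step close in size to a number 0.80 log units higher from compound 1 to compound 2 (beyond the scatter), which shows that an aromatic group at this position does not by itself bring the number down and that compound 1 stands apart from compound 2 and compound 4. Nothing shown here gives a measured reason for either step.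

The compounds shown leave open where a primary amine or a carboxylic acid on this aromatic carbon would fall relative to these three groups in this assay. They also leave open whether 1,3-dimethyl-1H-pyrazol-5-yl and 2-methyl-1H-imidazol-1-yl would stay this far apart on a different core, such as that of compound 3.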